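The source may report more compounds than this note shows. Statements on the series, on what has been measured and on what is new or still open speak of the compounds shown alone.

Measured compounds:
compound 1 `Cc1ccccc1-n1nc(C)c2c1NC(=O)[C@H](C)S[C@@H]2c1ccc(-c2cc3ccccc3o2)cc1`: 17%
compound 2 `Cc1nn(-c2ccccc2Br)c2c1C(c1ccc(Oc3ccccc3)cc1)SC(C)C(=O)N2`: 84%

Both compounds were tested in an assay on isolated protein for agonist activity at Bile acid receptor (Homo sapiens), read by AlphaScreen, with a stated time of 30 min; on this read-out higher numbers stand for larger maximal responses and lower numbers for smaller maximal responses. Compound 1 gives 17%, and compound 2 gives 84%. Of the two numbers, compound 1 has the lower one; compound 2 stands well above it, and that gap is beyond the usual scatter of repeated measurements. Compound 2 differs from compound 1 in more than one place at once, so these two values alone cannot say which part of the structure is responsible for the difference.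

Compound 3 `COc1ccccc1Oc1ccc([C@H]2S[C@@H](C)C(=O)Nc3c2c(C)nn3-c2ccccc2C)cc1` has not yet been measured in this assay. It differs from compound 1 in a single place: 2-methoxyphenoxy in place of 1-benzofuran-2-yl on an aromatic carbon. Among the measured compounds shown here, no measured pair of compounds shows exactly this change, so the size of the step can only be estimated. Starting from the low value of compound 1, 17%, there is more room for the number to rise than to fall. The step from compound 1 to compound 3 in this assay is expected to be a number 23 percentage points higher from compound 1 to compound 3 (beyond the scatter), an increase that may or may not reach beyond the scatter. For compound 3 the expected value in this assay is 40%, with a range from 15% to 75%.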

Compound 3, largest response reached (reported as efficacy), in percent of the reference or control that the assay uses: 240%
Beside the measured number, compound 3's estimate is 200 percentage points below it; the whole stated range lies below it.
By their numbers in this assay, from the lowest: compound 1; then compound 2; then compound 3.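

In this assay, putting 2-methoxyphenoxy in place of 1-benzofuran-2-yl on this aromatic carbon, para to a large group, gives a number 223 percentage points higher from compound 1 to compound 3 (beyond the scatter), so a change at this one place, with the rest of the structure kept, can shift the maximal response very strongly. The shift arises between two groups with the same count of 9 heavy atoms, so that count does not separate them; they differ in that 2-methoxyphenoxy has one six-membered aromatic ring and 2 hydrogen-bond acceptors, while 1-benzofuran-2-yl has a five-membered aromatic ring as well as a six-membered one and 1 hydrogen-bond acceptor. Nothing available here explains why this exchange has such a large effect.

As far as these compounds go, compound 2 also carries an oxygen-linked phenyl ring, but it differs from compound 3 in more than one place, so the share of the methoxy group in the step stays unknown. Also open, from the compounds shown here alone, is how the response would change if that methoxy group gave way to a hydroxyl group, an ethoxy group or an amine, or moved to another carbon of the ring.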